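Acyl change on the shared core: compound 1 to compound 4

The source may hold more compounds than are shown below. What is called first, only, known or untested is meant among the compounds shown, and "the series" means these compounds.

In an assay on isolated protein for inhibition of aldehyde dehydrogenase 1A1 (Homo sapiens), read by spectrophotometry, tested at 10 uM (a higher number here means more inhibition at the concentration tested (going by the name of the read-out), a lower number less inhibition), compound 1 `CCc1ccc(C(=O)N2CCN(Cc3nc4ccccc4n3Cc3cccc(C)c3)CC2)cc1` gives 67%, the highest of the three numbers; compound 2 `O=C(C1CC1)N1CCN(Cc2nc3ccccc3n2Cc2ccccc2C(F)(F)F)CC1` gives 56.3% and compound 3 `O=C(C1CC1)N1CCN(Cc2nc3ccccc3n2Cc2ccccc2F)CC1` gives 40.7%, both beyond the scatter below compound 1. Among the compounds with values here, the one measured step, a number 15.6 percentage points lower from compound 2 to compound 3 (beyond the scatter), concerns a fluoro in place of a trifluoromethyl on an aromatic carbon, a different place from the carbonyl carbon. Compound 4 `Cc1cccc(Cn2c(CN3CCN(C(=O)c4cccs4)CC3)nc3ccccc32)c1` differs from compound 1 by thiophen-2-yl in place of 4-ethylphenyl on a carbonyl carbon. Within the data shown here, no measured step touches the carbonyl carbon, so the direction cannot be read from the set; a modest fall is taken as the likelier outcome, with wide uncertainty. For compound 4 the expected value is 55%, estimated between 35% and 75%, an expected step of a number 12 percentage points lower from compound 1 to compound 4 (beyond the scatter).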

Compound 4, a percentage reported as inhibition, at one concentration (the size of the read-out at that concentration, not a potency): 60.8%
Compound 4: the middle estimate sits 5.8 percentage points below what was measured; measured number inside the range.
By their numbers in this assay, from the lowest: compound 3; then compounds 2, 4 and 1 (each within the scatter of the next, the first and the last beyond it).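

Thiophen-2-yl in place of 4-ethylphenyl on a carbonyl carbon gives a number 6.2 percentage points lower from compound 1 to compound 4 (within the scatter), the first step seen at this position. In this assay, the position therefore accepts a five-membered aromatic ring with sulfur, with fewer heavy atoms, in place of the six-membered carbon ring without a change beyond the scatter. No supporting measurement bears on why this is so.

Open, from the compounds shown here alone, is whether this holds on the carbonyl carbon for a group with no aromatic ring, such as piperidin-1-yl or a longer alkyl chain. Also open, going by these compounds, is how an amine or a carboxylic acid on the thiophene ring would read.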